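The source may hold more compounds than are shown below. What is called first, only, known or untested is meant among the compounds shown, and "the series" means these compounds.

Measured in a physicochemical assay for solubility, read by turbidimetry, in phosphate buffer, with a stated time of 24 h, at pH 7.4; a higher number here means a more soluble compound, a lower number a less soluble compound:
- compound 1 `CCNC(=O)Nc1nc2cc(-c3cnc(N4CCC(C(=O)O)CC4)nc3)cc(-c3ccccn3)c2s1`: > 800 ug/mL (a limit)
- compound 2 `CCNC(=O)Nc1nc2cc(-c3cnc(N4CCC(CC)(C(=O)O)CC4)nc3)cc(-c3ccccn3)c2s1`: > 800 ug/mL (a limit)
- compound 3 `CCNC(=O)Nc1nc2cc(-c3cnc(N4CCC(N)(C(=O)O)CC4)nc3)cc(-c3ccccn3)c2s1`: 25 ug/mL

Among the measured compounds shown here, compound 3 has the only actual number, and the rest of the set sits at the limit of > 800 ug/mL in this assay, at which 2 of the 3 values shown sit.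

Compound 4 `CCNC(=O)Nc1nc2cc(-c3cnc(N4CCC(C)(C(=O)O)C4)nc3)cc(-c3ccccn3)c2s1` carries 3-carboxy-3-methylpyrrolidin-1-yl in place of 4-amino-4-carboxypiperidin-1-yl on an aromatic carbon.

For the measured compounds named here, two measured steps bear on this, both large: amino in place of hydrogen gave an at least 32-fold lower number from compound 1 to compound 3 (1.50 log units; beyond the scatter), and amino in place of ethyl gave an at least 32-fold lower number from compound 2 to compound 3 (1.50 log units; beyond the scatter). Going by the values given here, compound 4 has no amino group, but no measured step covers the five-membered ring. A large rise is therefore expected, reversing those steps: a 32-fold higher number from compound 3 to compound 4 (1.51 log units; beyond the scatter). For compound 4 the estimate is 800 ug/mL, with an expected range of 200 ug/mL to 1000 ug/mL.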

Compound 4, solubility: > 800 ug/mL
Compound 4: a limit, no number; the forecaster's own chance of this, stated with the estimate: 65%; the middle value sits exactly at the limit.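

In this assay, 3-carboxy-3-methylpyrrolidin-1-yl in place of 4-amino-4-carboxypiperidin-1-yl on an aromatic carbon gave an at least 32-fold higher number from compound 3 to compound 4 (1.50 log units; beyond the scatter). Compound 4 reads as a limit, not a number, so its steps to compound 1 and compound 2 cannot be read, and neither can the step between those two. The five-membered ring thus joins the piperidines without an amino group, and compound 3 alone stands off the limit: the limit of > 800 ug/mL in this assay, at which 3 of the 4 values shown sit.

On these data alone, the step changes ring size and swaps amino for methyl at once, so the share of each stays open. An amine on the five-membered ring, in place of methyl, would separate the two.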